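The compounds below may be only part of what the source reports. "The series", "measured", "known", "first", "only" and "open" are said of these compounds alone.

Compound 1 `Cn1nc(CN2CCCC2)nc1-c1ccc(C(C)(C)C)cc1`: > 1000 nM. Compound 2 `Cc1ccc(-c2nc(CN3CCCC3)nn2C)cc1`: > 1000 nM.

In an assay on membranes from Jurkat cells for displacement of a labelled ligand from Sigma intracellular receptor 2 (Homo sapiens), read by scintillation counting, with a stated time of 1 h (on this read-out higher numbers stand for weaker inhibition and lower numbers for stronger inhibition), compound 1 gives > 1000 nM, which is a limit of the assay and not a number. Compound 2 gives > 1000 nM in this assay, again only a limit. The step that the two limits leave unreadable from compound 1 to compound 2 therefore cannot be read. Compound 3 `Cn1nc(CN2CCCC2)nc1-c1ccc(C(F)(F)F)cc1` differs from compound 2 by trifluoromethyl in place of methyl on an aromatic carbon. Going by the values given here, no measured step gives a readable size for such a change, because of the limit of > 1000 nM in this assay, at which 2 of the 2 values shown sit. Compound 3 is thus expected near 3000 nM, within 800 nM to 20000 nM, most likely again as a limit. The expected step is a step that the limit leaves unreadable from compound 2 to compound 3.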

Compound 3, inhibition constant: > 1000 nM
Compound 3 gave a limit, no number (the forecaster's own chance of this, stated with the estimate: 80%); the middle value lies beyond the limit too.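

No step among compound 1, compound 2 and compound 3 can be read in this assay, since each value is only a limit: the limit of > 1000 nM in this assay, at which 3 of the 3 values shown sit.

On these data alone, how strongly each compound inhibits, and whether swapping tert-butyl, methyl and trifluoromethyl on the aromatic carbon changes that, stays open.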